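Replacing the 4-cyano-3-fluorophenyl group of compound 2

The compounds below may be only part of what the source reports. "The series", "measured", "known", "first", "only" and "open" are said of these compounds alone.

Of the compounds shown here, two with a shared core have been measured in a functional assay on EBC-1 cells (Homo sapiens) for antiproliferative activity, with a stated time of 72 h; a higher number here means a weaker inhibitor, a lower number a stronger inhibitor. Compound 1 `OCCn1cc(-c2cc(F)c3ncc(Cc4ccc5ncccc5c4)n3c2)cn1`, which carries a 1-(2-hydroxyethyl)-1H-pyrazol-4-yl group, gives 0.34 nM. Compound 2 `N#Cc1ccc(-c2cc(F)c3ncc(Cc4ccc5ncccc5c4)n3c2)cc1F`, which carries a 4-cyano-3-fluorophenyl group on the same aromatic carbon, gives 145 nM, the higher and therefore weaker of the two numbers. Among the compounds with values here, the only measured step is a 430-fold higher number from compound 1 to compound 2 (2.63 log units; beyond the scatter), so a change at this carbon has already moved the number by a large amount.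

Compound 3 `CCO/N=C(\C)c1cc(F)c2ncc(Cc3ccc4ncccc4c3)n2c1` keeps the core and changes that carbon again: a group of 6 heavy atoms (4 carbon, 1 nitrogen, 1 oxygen; no ring) in place of a group of 9 heavy atoms (7 carbon, 1 nitrogen, 1 fluorine; one six-membered aromatic ring of carbon only), on an aromatic carbon. Within the data shown here, no measured compound has a group without a ring here, so the single step is only a loose guide. It does show how much room lies below compound 2, and a result inside the span of the two measured numbers seems most likely. In this assay, the expected change is a 12-fold lower number from compound 2 to compound 3 (1.08 log units; beyond the scatter), a moderate step towards stronger inhibition and beyond the scatter. Compound 3 is estimated at 12 nM, with an expected range of 1.5 nM to 70 nM.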

Compound 3, half-maximal inhibitory concentration: 1480 nM
The estimate for compound 3 lay 120-fold (2.09 log units) below the measured number; the whole stated range lies below it.
By their numbers in this assay, from the lowest: compound 1; then compound 2; then compound 3.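

In this assay, the group without a ring sits at the weak end of the series, with a 10-fold higher number from compound 2 to compound 3 (1.01 log units; beyond the scatter) and, measured against the 1-(2-hydroxyethyl)-1H-pyrazol-4-yl group, a 4400-fold higher number from compound 1 to compound 3 (3.64 log units; beyond the scatter). Within the data shown here, both groups carrying an aromatic ring at this carbon therefore give lower numbers than the single group without one, and the room for change at this position now spans a much wider range than the first two compounds showed, while the heavy-atom counts of 8, 9 and 6, taken in order of rising number, show that group size alone does not set the order. Nothing available here explains this order.

Among these compounds, with only one group without a ring, it remains open whether the loss of the ring or some other feature of this particular chain accounts for the high number. On these data alone, it also remains open how much of the low number of compound 1 comes from the pyrazole ring and how much from its 2-hydroxyethyl chain, which a plain 1-methylpyrazole at the same carbon would help to separate.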